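Changing the ring on compound 2

The source may report more compounds than this note shows. Statements on the series, on what has been measured and on what is new or still open speak of the compounds shown alone.

In a functional assay on HL-60 cells (Homo sapiens) for cytotoxicity, read by MTT assay, with a stated time of 72 h (on this read-out lower numbers stand for stronger inhibition and higher numbers for weaker inhibition), three compounds share one core and differ in a single aromatic substituent: compound 1 `Cc1ccc(S(=O)(=O)c2nc3ccccc3nc2N2CCCC2)cc1` gives 9720 nM, compound 2 `COc1ccc(S(=O)(=O)c2nc3ccccc3nc2N2CCCC2)cc1` gives 16000 nM, and compound 3 `O=S(=O)(c1ccc(Br)cc1)c1nc2ccccc2nc1N1CCCC1` gives 6070 nM. The data show a 1.6-fold higher number from compound 1 to compound 2 (0.22 log units; within the scatter), and then a 2.6-fold lower number from compound 2 to compound 3 (0.42 log units; beyond the scatter), so compound 2 sits at the high end, clearly so only against compound 3. Compound 4 `COc1ccc(S(=O)(=O)c2nc3ccccc3nc2N2CCCC(O)C2)cc1` has 3-hydroxypiperidin-1-yl in place of pyrrolidin-1-yl on an aromatic carbon. Within the data shown here, no measured step touches this place, so those steps offer only a rough scale, and no change beyond the scatter is expected. The expected step is a 1.3-fold higher number from compound 2 to compound 4 (0.10 log units; within the scatter). Compound 4 is estimated at 20000 nM, within an expected range of 7000 nM to 55000 nM.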

Compound 4, half-maximal inhibitory concentration: 3050 nM
Compound 4: the middle estimate sits 6.6-fold (0.82 log units) above what was measured; measured number below the stated range.
By their numbers in this assay, from the lowest: compounds 4, 3, 1 and 2 (each within the scatter of the next, the first and the last beyond it).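

Among these compounds, the earlier compounds varied only one aromatic substituent, while this change is the first at the place held by pyrrolidin-1-yl: in this assay, 3-hydroxypiperidin-1-yl there gives a 5.2-fold lower number from compound 2 to compound 4 (0.72 log units; beyond the scatter). This place therefore responds to change, by more than any step among the aromatic substituents. No evidence on why is available here. The swap enlarges the ring and adds a hydroxyl together, so the compounds shown cannot separate those two changes. Plain piperidin-1-yl or 3-hydroxypyrrolidin-1-yl would be needed to tell them apart.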